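The source may hold more compounds than are shown below. What is called first, only, known or untested is meant among the compounds shown, and "the series" means these compounds.

- Compound 1 `COc1ccc(C[C@H]2COC(=O)[C@@H]2Cc2ccc(OC(=O)CCC(=O)N3CCCC3)c(OC)c2)cc1OC` gives 201000 nM
- Compound 2 `COc1ccc(C[C@H]2COC(=O)[C@@H]2Cc2ccc(OCc3cn(Cc4ccccc4)nn3)c(OC)c2)cc1OC` gives 346000 nM

In an ADME assay on HeLa cells (Homo sapiens) for cytotoxicity, read by MTT assay (on this read-out lower numbers stand for stronger inhibition and higher numbers for weaker inhibition), compound 2 at 346000 nM lies within the usual scatter of compound 1 (201000 nM), so these two numbers cannot be told apart. Compound 3 (`COc1ccc(C[C@H]2COC(=O)[C@@H]2Cc2ccc(OCc3cn(-c4ccccc4)nn3)c(OC)c2)cc1OC`) differs from compound 2 by carrying phenyl in place of benzyl on an aromatic nitrogen. Among the measured compounds shown here, no measured pair shows this kind of change, so in this assay no step beyond the scatter is expected. The estimated step, a 1.2-fold lower number from compound 2 to compound 3 (0.09 log units; within the scatter) (within the scatter), reflects that expectation. For compound 3 the estimate is 280000 nM (expected range 120000 nM to 600000 nM).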

Compound 3, half-maximal inhibitory concentration: 124000 nM
Estimate against measurement, compound 3: 2.3-fold (0.35 log units) above, and the stated range covers the measured number.
By their numbers in this assay, from the lowest: compounds 3, 1 and 2 (each within the scatter of the next, the first and the last beyond it).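

In this assay, phenyl in place of benzyl on the aromatic nitrogen gives a 2.8-fold lower number from compound 2 to compound 3 (0.45 log units; beyond the scatter), the first step shown to pass the scatter, so this small swap on the triazole does register. Replacing the whole group on the oxygen on an aromatic ring gives a 1.6-fold lower number from compound 1 to compound 3 (0.21 log units; within the scatter), so that much broader exchange cannot be told apart. Nothing available explains the step with phenyl.

From the compounds shown here alone, it stays open whether a phenyl carrying an amine or a carboxylic acid, or a longer chain such as phenethyl on that nitrogen, would move the number further.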